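Imidazole Methylation and Half-life in the Shared Core

A few compounds are considered here, and "the series" means these few. Any claim that something is new, unique, unknown or untested is made for them only; others in the source may bear on it.

Compound 1, `CC(C)C(c1ncc[nH]1)c1ccc(-c2ccc3cccc(F)c3c2)[nH]c1=O`: < 0.0667 h
Compound 2, `CC(C)C(c1noc(=O)[nH]1)c1ccc(-c2ccc3cccc(F)c3c2)[nH]c1=O`: > 3 h
Compound 3, `CC(C)C(c1ncco1)c1ccc(-c2ccc3cccc(F)c3c2)[nH]c1=O`: 0.08 h

In an ADME assay on microsomes from liver (Mus musculus) for metabolic stability (on this read-out lower numbers stand for a shorter-lived compound and higher numbers for a longer-lived compound), compound 1 gives < 0.0667 h, which is a limit of the assay and not a number; this is the limit of < 0.0667 h in this assay, at which 1 of the 3 values shown sits. Compound 2 also gives only a limit, > 3 h, which is the limit of > 3 h in this assay, at which 1 of the 3 values shown sits. Compound 3 gives 0.08 h. Among these three, the ring swap that brings in three hetero atoms stands out: an at least 44-fold higher number from compound 1 to compound 2 (1.65 log units; beyond the scatter), and in the reverse sense an at least 37-fold lower number from compound 2 to compound 3 (1.57 log units; beyond the scatter). The swap between the two rings with 2 hetero atoms is different: an at least 1.1-fold higher number from compound 1 to compound 3 (0.07 log units; that floor lies within the scatter).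

Compound 4, `Cc1nc(C(c2ccc(-c3ccc4cccc(F)c4c3)[nH]c2=O)C(C)C)[nH]c1C`, differs from compound 1 only in this: 4,5-dimethyl-1H-imidazol-2-yl in place of 1H-imidazol-2-yl on a saturated chain carbon bound to an aromatic carbon and a saturated chain carbon. Among the measured compounds shown here, no measured step adds methyl groups to a ring; the nearest precedent is the step from compound 1 to compound 3, where the ring with 2 hetero atoms is kept and the number stays within the scatter. Compound 1 therefore sets the starting point at a short-lived limit. For compound 4 a step of an at least 1.4-fold higher number from compound 1 to compound 4 (0.17 log units; that floor lies within the scatter) is expected, that is, nothing clearly beyond the scatter. Compound 4 is estimated at 0.1 h, expected to lie between 0.03 h and 0.5 h.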

Compound 4, half-life: 0.0817 h
The estimate for compound 4 lay 1.2-fold (0.09 log units) above the measured number, within the range that was stated.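

With 4,5-dimethyl-1H-imidazol-2-yl on the saturated chain carbon, the result in this assay shows that putting methyl groups on the imidazole ring brings no step beyond the scatter that can be read, with an at least 1.2-fold higher number from compound 1 to compound 4 (0.08 log units; that floor lies within the scatter), and the comparison with the oxazole ring gives a 1.0-fold higher number from compound 3 to compound 4 (0.01 log units; within the scatter). Compound 4 thus stays with compounds 1 and 3 among the short-lived compounds, while the gap to the ring with 3 hetero atoms remains large, with an at least 36-fold lower number from compound 2 to compound 4 (1.56 log units; beyond the scatter). The comparison with compound 1 rests on a limit of the assay and not on a number: the limit of < 0.0667 h in this assay, at which 1 of the 4 values shown sits.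

On these data alone, how far up compound 2 actually lies stays open, and its value too is a limit of the assay: the limit of > 3 h in this assay, at which 1 of the 4 values shown sits. Whether a tetrazole or a carboxylic acid on this saturated chain carbon would fall with compound 2 or with compounds 1, 3 and 4 also remains open.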